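Compound 4: 2-fluorophenyl in place of 3-fluorophenyl

The source may report more compounds than this note shows. Statements on the series, on what has been measured and on what is new or still open speak of the compounds shown alone.

For the measured compounds named here, in a functional assay on MCF-10A cells (Homo sapiens) for antiproliferative activity, with a stated time of 48 h (a lower number here means that less compound is needed, a higher number that more compound is needed for the effect), compound 3 (`COc1ccc2nc(C)cc(NCc3cccc(F)c3)c2c1`) gives 11300 nM as the lowest of the three numbers so far. Compound 1 (`COc1ccc2nc(C)cc(NCc3ccncc3)c2c1`) gives 40900 nM and compound 2 (`COc1ccc2nc(C)cc(NCc3cccnc3)c2c1`) gives 44800 nM at the higher end, with a 1.1-fold higher number from compound 1 to compound 2 (0.04 log units; within the scatter) between them. Compound 4 (`COc1ccc2nc(C)cc(NCc3ccccc3F)c2c1`) has 2-fluorophenyl in place of 3-fluorophenyl on a saturated chain carbon bound to a nitrogen on an aromatic ring. The nearest evidence is indirect, since a 3.6-fold lower number from compound 1 to compound 3 (0.56 log units; beyond the scatter) and a 4.0-fold lower number from compound 2 to compound 3 (0.60 log units; beyond the scatter) both exchange a pyridinyl group for 3-fluorophenyl. Going by the values given here, no measured step exchanges one fluorophenyl for another, so no shift beyond the scatter is expected, and a 1.2-fold higher number from compound 3 to compound 4 (0.06 log units; within the scatter) is the estimated step. Compound 4 is expected at 13000 nM within a range of 6000 nM to 28000 nM in this estimate.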

Compound 4, half-maximal effective concentration: 14000 nM
Compound 4: the middle estimate sits 1.1-fold (0.03 log units) below what was measured, and the stated range covers the measured number.
By their numbers in this assay, from the lowest: compounds 3 and 4 (each within the scatter of the next); then compounds 1 and 2 (each within the scatter of the next).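

In this assay, for the compounds shown here, this is the first exchange of one fluorophenyl for another, and a 1.2-fold higher number from compound 3 to compound 4 (0.09 log units; within the scatter) shows that 2-fluorophenyl and 3-fluorophenyl cannot be told apart here. The separation from the pyridinyl compounds also holds for 2-fluorophenyl, with a 3.2-fold lower number from compound 2 to compound 4 (0.51 log units; beyond the scatter) and a 2.9-fold lower number from compound 1 to compound 4 (0.47 log units; beyond the scatter) in this series. No measured evidence bears on why these steps take this size.

Open is whether the fluorine contributes at all, since plain phenyl is not among the compounds shown. Also open, going by these compounds, is how chlorophenyl, methoxyphenyl or a longer chain in place of the single carbon would compare.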